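Amide for ester in a hydrazinyl-urea series

The source may report more compounds than this note shows. Statements on the series, on what has been measured and on what is new or still open speak of the compounds shown alone.

Compound 2 `CCOC(=O)c1cc(C)cc(NNC(=O)Nc2cc(Cl)nc(Cl)c2)n1` stands at the assay ceiling in a functional assay on CHO cells for agonist activity at sphingosine 1-phosphate receptor 2 (Homo sapiens), read by fluorescence and calcium flux, with a stated time of 3 min; a lower number here means a stronger inhibitor, a higher number a weaker inhibitor; in this assay compound 2 gives > 23000 nM, which is a limit and not a number. Compound 1 `Cc1cc(NNC(=O)Nc2cc(Cl)nc(Cl)c2)ncc1C#N` gives > 23000 nM in this assay, also a limit. Compound 3 `Cc1cc(NNC(=O)Nc2cc(Cl)nc(Cl)c2)ncc1-c1cn(C)nc1C` gives > 23000 nM in this assay, again a limit. Among the compounds with values here, all three share (the limit of > 23000 nM in this assay, at which 3 of the 3 values shown sit), so the one measured step, a step that the two limits leave unreadable from compound 1 to compound 3, is unreadable and gives no guide to size. Compound 4 `Cc1cc(NNC(=O)Nc2cc(Cl)nc(Cl)c2)nc(C(=O)N(C)C2CC2)c1` carries cyclopropyl(methyl)amino in place of ethoxy on a carbonyl carbon. Within the data shown here, no measured step touches the carbonyl carbon, and no value shown leaves the limit. Compound 4 is therefore expected to remain at the limit, with an estimated 30000 nM in this assay (range 15000 nM to 80000 nM). The estimated step that the limit leaves unreadable from compound 2 to compound 4 is expected to stay within the scatter.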

Compound 4, half-maximal inhibitory concentration: > 23000 nM
Compound 4: no number, only a limit (the forecaster's own chance of this, stated with the estimate: 85%); the middle value lies beyond the limit too.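

The step from compound 2 to compound 4 cannot be read, since both compounds give only a limit: the limit of > 23000 nM in this assay, at which 4 of the 4 values shown sit.

As far as these compounds go, whether any change to the shared core gives a measurable value in this assay remains open.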